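From pyridin-4-yl to pyridin-2-yl on the amine nitrogen

The source may hold more compounds than are shown below. What is called first, only, known or untested is meant among the compounds shown, and "the series" means these compounds.

Compound 1 `Cc1c(C)c2c(c(C)c1O)CCC(C)(CN1CCCC1)O2` bears a pyrrolidin-1-yl group, and in a functional assay (brain) for inhibition, with Rattus norvegicus as the target (on this read-out higher numbers stand for weaker inhibition and lower numbers for stronger inhibition), compound 1 gives 1400 nM. Compound 2 `Cc1c(C)c2c(c(C)c1O)CCC(C)(CNc1ccncc1)O2` gives 16000 nM, the higher of the two numbers measured. For the measured compounds named here, the only measured step is an 11-fold higher number from compound 1 to compound 2 (1.06 log units; beyond the scatter), and it exchanges one whole group for another. Going by the values given here, compound 3 `Cc1c(C)c2c(c(C)c1O)CCC(C)(CNc1ccccn1)O2` differs from compound 2 by pyridin-2-yl in place of pyridin-4-yl on an amine nitrogen, the same atoms joined differently, so no measured step bears on this change directly, and no step beyond the scatter is expected. For compound 3 the estimate is 16000 nM, between 6000 nM and 40000 nM, which means an expected no change at the digits printed from compound 2 to compound 3 (within the scatter).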

Compound 3, half-maximal inhibitory concentration: 200 nM
Compound 3: the middle estimate sits 80-fold (1.90 log units) above what was measured; measured number outside the range, below it.
By their numbers in this assay, from the lowest: compound 3; then compound 1; then compound 2.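

In this assay, changing only where the ring nitrogen sits gives an 80-fold lower number from compound 2 to compound 3 (1.90 log units; beyond the scatter), so at this place on the amine nitrogen the arrangement of the same atoms can matter as much as exchanging a whole group. The order of the amines also reverses, with a 7.0-fold lower number from compound 1 to compound 3 (0.85 log units; beyond the scatter), so a pyridinylamino group is not in itself a poorer choice than pyrrolidin-1-yl. Nothing available explains why the position of the ring nitrogen has this effect.

Going by these compounds, whether pyridin-3-yl would fall nearer compound 2 or compound 3 remains open. Also open, on these data alone, is whether phenyl, whose ring holds only carbon, would keep the number of compound 3.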